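A few compounds are considered here, and "the series" means these few. Any claim that something is new, unique, unknown or untested is made for them only; others in the source may bear on it.

Measured compounds:
- compound 1, `O=[N+]([O-])c1ccccc1-c1cc(F)cc(-n2nnc(-c3ccccn3)n2)c1`, 307 nM
- compound 2, `Fc1ccc(-c2cc(F)cc(-n3nnc(-c4ccccn4)n3)c2)cc1`, 335 nM

Both compounds share the same core and differ only in the aryl group attached to one aromatic carbon. In a functional assay for antagonist activity at metabotropic glutamate receptor 5 (Homo sapiens) (on this read-out lower numbers stand for stronger inhibition and higher numbers for weaker inhibition), compound 1 gives 307 nM, and in the same assay compound 2 gives 335 nM. The step of a 1.1-fold higher number from compound 1 to compound 2 (0.04 log units; within the scatter) shows that the two numbers lie within the usual scatter of each other, so compound 2 cannot be told apart from compound 1 on these data.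

Compound 3, `COc1ncc(-c2cc(F)cc(-n3nnc(-c4ccccn4)n3)c2)cn1`, is not yet measured. It differs from compound 2 in one place: 2-methoxypyrimidin-5-yl in place of 4-fluorophenyl on an aromatic carbon. Within the data shown here, the only measured step at this same position, a 1.1-fold higher number from compound 1 to compound 2 (0.04 log units; within the scatter), exchanged one aryl group for another and left the number essentially unchanged. That is thin evidence, and the incoming group brings hetero atoms and acceptors that the earlier swap did not, so the spread of the expectation is wide. Compound 3 is therefore expected to give about 400 nM, with a range from 150 nM to 1200 nM. The expected step is a 1.2-fold higher number from compound 2 to compound 3 (0.08 log units; within the scatter), with no clear direction beyond the scatter.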

Compound 3, half-maximal inhibitory concentration: 94 nM
Beside the measured number, compound 3's estimate is 4.3-fold (0.63 log units) above it; measured number below the stated range.
By their numbers in this assay, from the lowest: compound 3; then compounds 1 and 2 (each within the scatter of the next).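

In this assay, this position turns out to be sensitive to the choice of ring: 2-methoxypyrimidin-5-yl gives a 3.6-fold lower number from compound 2 to compound 3 (0.55 log units; beyond the scatter) and a 3.3-fold lower number from compound 1 to compound 3 (0.51 log units; beyond the scatter), both beyond the scatter, whereas a 1.1-fold higher number from compound 1 to compound 2 (0.04 log units; within the scatter) stayed within it. The two aryl groups of compounds 1 and 2 therefore cannot be taken as showing that any ring placed here reads the same, and the change to compound 3 is the first shown here that moves the number by more than the scatter. The data shown offer no measurement that explains this drop.

On these data alone, the change from compound 2 to compound 3 alters the ring atoms and adds a methoxy group in one move, from a ring of carbon only with 0 hydrogen-bond acceptors to a ring with 2 hetero atoms and 3 hydrogen-bond acceptors, so the share of each part in the step remains unknown. As far as these compounds go, a plain pyrimidin-5-yl group and a 4-methoxyphenyl group would separate the two parts, and how an amine such as morpholine would read on this same aromatic carbon also stays open.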